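This account rests on a few compounds, and the source may have more. Where it says the series, first, only, none or still open, it means among the compounds named here.

Measured compounds in a functional assay on ECa-109 cells for inhibition, with ECa-109 cell line (Homo sapiens) as the target, read by MTT assay, with a stated time of 48 h; on this read-out lower numbers stand for stronger inhibition and higher numbers for weaker inhibition: compound 1 `COc1cc(Nc2nc(Nc3ccc(Cl)cc3)nnc2Cl)cc(OC)c1OC` gives 32600 nM; compound 2 `COc1ccc(Nc2nnc(Cl)c(Nc3cc(OC)c(OC)c(OC)c3)n2)cc1` gives 22300 nM.

Among the measured compounds shown here, compound 1 stands at the highest of the two numbers; the only step, a 1.5-fold lower number from compound 1 to compound 2 (0.16 log units; within the scatter), is within the scatter. Compound 3 `COc1cc(Nc2nc(Nc3ccc4c(ccn4C)c3)nnc2Cl)cc(OC)c1OC` differs from compound 1 by 1-methyl-1H-indol-5-yl in place of 4-chlorophenyl on a nitrogen on an aromatic ring. For the measured compounds named here, no measured step changes the group on that nitrogen to a fused bicyclic aryl, so the one step at hand bears on it only loosely and was small. For this assay a step of a 1.6-fold lower number from compound 1 to compound 3 (0.21 log units; within the scatter) is expected, with no clear direction beyond the scatter. Compound 3 is estimated at 20000 nM, range 6000 nM to 60000 nM.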

Compound 3, half-maximal inhibitory concentration: 42100 nM
The estimate for compound 3 lay 2.1-fold (0.32 log units) below the measured number; low and high end bracket the measured number.
By their numbers in this assay, from the lowest: compounds 2, 1 and 3 (each within the scatter of the next).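

In this assay, 1-methyl-1H-indol-5-yl in place of 4-chlorophenyl on this nitrogen gives a 1.3-fold higher number from compound 1 to compound 3 (0.11 log units; within the scatter), and in place of 4-methoxyphenyl it gives a 1.9-fold higher number from compound 2 to compound 3 (0.28 log units; within the scatter). A group with a second aromatic ring, five-membered and holding a hetero atom, therefore does not separate compound 3 from compound 1 or compound 2 at this position. No available data bear on the reason for this result.

Open, going by these compounds, is whether any group on this nitrogen moves the number beyond the scatter. A carboxylic acid or a morpholine on the aromatic ring would test this.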